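The compounds below may be only part of what the source reports. "The series", "measured", "known", "first", "only" and "open" are said of these compounds alone.

Measured compounds in a functional assay on SNB-75 cells (Homo sapiens) for inhibition, read by sulforhodamine B assay, with a stated time of 48 h; on this read-out lower numbers stand for stronger inhibition of growth and higher numbers for weaker inhibition of growth:
- compound 1 `COc1ccc(CNc2nc3cc(N)cc(N)c3nc2-c2ccccc2)cc1OC` gives 39800 nM
- compound 2 `CCOC(=O)[C@H](CCC(=O)O)NC(=O)c1ccc(Sc2nc3cc(N)cc(N)c3nc2-c2ccccc2)cc1` gives 63100 nM

Compound 1 has the lowest of the two numbers recorded in this assay; compound 2 stands close to it, and the gap between their two values lies within the usual scatter of the measurement, so no order between them can be claimed. Among the compounds with values here, no step between two measured compounds is available that would show what a single change on the shared core does.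

Compound 3 `COc1cc(CNc2nc3cc(N)cc(N)c3nc2-c2ccccc2)cc(OC)c1OC` has not yet been measured. It differs from compound 1 by one change: methoxy in place of hydrogen on an aromatic carbon. Within the data shown here, with no measured step of this kind to draw on, the expected step in this assay from compound 1 to compound 3 is a 1.0-fold higher number from compound 1 to compound 3 (0.00 log units; within the scatter), which amounts to no movement beyond the scatter in either direction. On this basis compound 3 is estimated to give 40000 nM in this assay, within a range from 15000 nM to 100000 nM.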

Compound 3, concentration for total growth inhibition: 14500 nM
Beside the measured number, compound 3's estimate is 2.8-fold (0.44 log units) above it, and the stated range ends above it.
By their numbers in this assay, from the lowest: compound 3; then compounds 1 and 2 (each within the scatter of the next).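

Within the data shown here, compound 3 gives the first step on the shared core that can be read. In this assay methoxy in place of hydrogen on an aromatic carbon, ortho to a methoxy group and meta to a large group, gives a 2.7-fold lower number from compound 1 to compound 3 (0.44 log units; beyond the scatter) and moves the number beyond the scatter. This shows that growth inhibition responds to a modest change at this position, even where two methoxy groups already stand on the ring, though nothing shown here bears on the reason for the step.

The compounds shown leave open whether the step is specific to methoxy or would also follow from a hydroxyl, a fluorine atom, an amine or a longer chain such as ethoxy at this carbon. They also do not show whether the same change would move the number on a compound lacking the two existing methoxy groups.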